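The compounds below may be only part of what the source reports. "The series", "measured", "known", "first", "only" and "open" are said of these compounds alone.

Measured compounds:
- compound 1, `FC(F)(F)c1ccc(CSc2nc(N3CCCCC3)c3ccccc3n2)cc1`: > 50000 nM in a functional assay on HGC-27 cells (Homo sapiens) for cytotoxicity, read by MTT assay, with a stated time of 72 h; a lower number here means a stronger inhibitor, a higher number a weaker inhibitor
- compound 2, `FC(F)(F)c1ccc(CSc2nc(Nc3ccccc3Cl)c3ccccc3n2)cc1`: > 50000 nM
- compound 3, `O=[N+]([O-])c1ccc(Nc2nc(SCc3ccc(C(F)(F)F)cc3)nc3ccccc23)cc1`: 16600 nM

Compound 2 stands at a limit of this assay, the value > 50000 nM being a limit and not a number; compound 1 sits at the same limit, with the limit of > 50000 nM in this assay, at which 2 of the 3 values shown sit. Compound 3 is the only one of the three with a measured number, 16600 nM, and the step of an at least 3.0-fold lower number from compound 2 to compound 3 (0.47 log units; beyond the scatter) shows that replacing 2-chlorophenyl by 4-nitrophenyl on the nitrogen on the aromatic ring brought the number into the readable range. The step that the two limits leave unreadable from compound 1 to compound 2 cannot be read at all.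

Compound 4, `FC(F)(F)c1ccc(CSc2nc(Nc3ccc(C(F)(F)F)cc3)c3ccccc3n2)cc1`, differs from compound 2 by 4-(trifluoromethyl)phenyl in place of 2-chlorophenyl on a nitrogen on an aromatic ring. Going by the values given here, the only step that bears on it is the one from compound 2 to compound 3, where another group in place of 2-chlorophenyl gave a readable number; 4-(trifluoromethyl)phenyl itself has not been tested at this position. An estimated step of an at least 1.6-fold lower number from compound 2 to compound 4 (0.22 log units; that floor lies within the scatter) is therefore expected for compound 4, possibly leaving it near the limit. The estimate for compound 4 is 30000 nM, expected between 10000 nM and 80000 nM.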

Compound 4, half-maximal inhibitory concentration: 7560 nM
The estimate for compound 4 lay 4.0-fold (0.60 log units) above the measured number, outside the stated range (below it).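

In this assay, 4-(trifluoromethyl)phenyl on the nitrogen gives an at least 6.6-fold lower number from compound 2 to compound 4 (0.82 log units; beyond the scatter), and the whole (4-(trifluoromethyl)phenyl)amino group in place of piperidin-1-yl gives an at least 6.6-fold lower number from compound 1 to compound 4 (0.82 log units; beyond the scatter), so a second group at this place now brings a readable number. Both of these steps start from a limit and not a number: the limit of > 50000 nM in this assay, at which 2 of the 4 values shown sit. Going by these compounds alone, what the earlier compounds could not give is a comparison of two measured numbers at this place: trifluoromethyl in place of nitro on an aromatic carbon gives a 2.2-fold lower number from compound 3 to compound 4 (0.34 log units; beyond the scatter).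

The compounds shown leave open whether a nitrile, a methoxy group or a carboxylic acid in place of trifluoromethyl would carry the number further in either direction. They also leave open whether an unsubstituted phenyl on that nitrogen would give a readable number at all.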